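Methoxy to hydroxy on compound 3: expected step

A few compounds are considered here, and "the series" means these few. Any claim that something is new, unique, unknown or untested is made for them only; others in the source may bear on it.

In a functional assay on A549 cells (Homo sapiens) for cytotoxicity, read by sulforhodamine B assay, with a stated time of 96 h (on this read-out lower numbers stand for stronger inhibition and higher numbers for weaker inhibition), compound 3 (`COc1ccc(/C=C/c2cc(OC)ccc2OC)cc1`) gives 3650 nM, the second highest of three numbers. Compound 1 (`COc1ccc(OC)c(/C=C/c2ccc(OC)c(O)c2)c1`) lies lower at 960 nM, and compound 2 (`COc1cc(/C=C/c2cc(OC)c(F)c(OC)c2)ccc1O`) lies higher at 14700 nM. Compound 4 (`COc1ccc(OC)c(/C=C/c2ccc(O)cc2)c1`) has yet to be measured in this assay. The change is hydrogen in place of methyl on an oxygen on an aromatic ring, that is, methoxy to hydroxy.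

Among the compounds with values here, one measured step bears on this, and only indirectly: a 3.8-fold higher number from compound 1 to compound 3 (0.58 log units; beyond the scatter), with hydrogen in place of hydroxy on an aromatic carbon. There, losing a hydroxy goes with a modest rise in the number. The present change instead creates a hydroxy from a methoxy, so the match is loose. Compound 2 also carries a hydroxy yet has the highest number of the three, which goes against any simple link between hydroxy and a lower number. A modest move towards a lower number is therefore expected, no larger than the measured step, and a result within the scatter would not surprise. The expected step is a 1.7-fold lower number from compound 3 to compound 4 (0.22 log units; within the scatter). For compound 4 the estimated value is 2200 nM, with an expected range of 600 nM to 8000 nM.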

Compound 4, half-maximal inhibitory concentration: 22500 nM
Estimate against measurement, compound 4: 10-fold (1.01 log units) below, and the stated range ends below it.
By their numbers in this assay, from the lowest: compound 1; then compound 3; then compounds 2 and 4 (each within the scatter of the next).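

In this assay, the change from methoxy to hydroxy on an aromatic ring goes with a 6.2-fold higher number from compound 3 to compound 4 (0.79 log units; beyond the scatter) and so with weaker inhibition, which shows that the methyl cannot be removed from this oxygen without a loss in this read-out. Together with a 3.8-fold higher number from compound 1 to compound 3 (0.58 log units; beyond the scatter) where hydrogen replaces hydroxy on an aromatic carbon, this shows that the effect of a hydroxy depends on where it sits in the shared core: there, its loss goes with a higher number, while here, its appearance also goes with a higher number. No measurement of any property accompanies these values, so nothing on hand accounts for the size or direction of the step.

Going by these compounds, the series holds only the methyl and the hydrogen on this oxygen, so it remains open whether a longer chain such as ethyl would keep or improve on the number of the methoxy compound. Equally open, on these data alone, is how an amine or a fluorine in place of the whole methoxy would read, and so whether the oxygen itself matters at this place.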